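A Fluoro-to-Methyl Swap Tested Against a Weak Starting Point

The source may report more compounds than this note shows. Statements on the series, on what has been measured and on what is new or still open speak of the compounds shown alone.

Compound 2 `O=S(=O)(c1ccc(F)cc1)N1CC(c2nc(-c3cccc(Cl)c3)no2)C1` and compound 1 `Cc1ccc(S(=O)(=O)N2CC(c3nc(-c4cccc(Cl)c4)no3)C2)cc1` share one core and differ in a single place: methyl in place of fluoro on an aromatic carbon. In an assay on HEK293 cells for negative allosteric modulation of metabotropic glutamate receptor 5 (Homo sapiens), read by FLIPR (on this read-out higher numbers stand for weaker inhibition and lower numbers for stronger inhibition), compound 2 gives 130 nM. Compound 1 gives 920 nM in this assay, so the swap brought a 7.1-fold higher number from compound 2 to compound 1 (0.85 log units; beyond the scatter). Compound 3 `O=C(C1CCC(C(F)(F)F)CC1)N1CC(c2nc(-c3cccc(F)c3)no2)C1` is built on another core; how that core differs from the core of compound 2 is not broken down here. In this assay compound 3 gives > 10000 nM, which is the limit of > 10000 nM in this assay, at which 1 of the 3 values shown sits, and not a number. Compound 4 `Cc1cccc(-c2noc(C3CN(C(=O)C4CCC(C(F)(F)F)CC4)C3)n2)c1` carries the same kind of change made on compound 3: methyl in place of fluoro on an aromatic carbon. Around the place the two cases are not identical, since in compound 1 the methyl sits para to a large group and in compound 4 meta to a large group. Because the measured step gave a 7.1-fold higher number from compound 2 to compound 1 (0.85 log units; beyond the scatter), a weakening, and compound 3 already sits at the limit, compound 4 is expected to remain at or past that limit. The step from compound 3 to compound 4 is estimated at a step that the limit leaves unreadable from compound 3 to compound 4 in this assay. Compound 4 is therefore expected near 30000 nM in this assay, between 8000 nM and 100000 nM.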

Compound 4, half-maximal inhibitory concentration: > 10000 nM
Compound 4: a limit, no number; the forecaster's own chance of this, stated with the estimate: 85%; the middle value is on the limit's open side.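

In this assay compound 3 and compound 4 both stand at a limit and not at a number, so no step between the two can be read: the limit of > 10000 nM in this assay, at which 2 of the 4 values shown sit.

The compounds shown leave open whether methyl in place of fluoro on an aromatic carbon changes inhibition at all on the core of compound 3.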